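Methyl in Place of Dimethylsulfamoyl: Expected Cell Tolerance

This account rests on a few compounds, and the source may have more. Where it says the series, first, only, none or still open, it means among the compounds named here.

Of the compounds shown here, three have been measured in an ADME assay on Huh-7 cells (Homo sapiens) for cytotoxicity; a higher number here means that more compound is tolerated, a lower number that less compound is tolerated. Compound 1 `CN1CCN(CCNCc2cn(-c3ccc(F)cc3F)nc2-c2ccc(OC(F)(F)F)cc2)CC1` gives 18000 nM. For compound 2 `CN1CCN(CCNCc2cn(-c3ccc(F)cc3F)nc2-c2ccccc2)CC1` this assay reports only a limit, > 20000 nM. For compound 3 `CN1CCN(CCNCc2cn(-c3ccc(F)cc3F)nc2-c2ccc(S(=O)(=O)N(C)C)cc2)CC1` this assay likewise reports only a limit, > 20000 nM.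

Compound 3 therefore stands not at a number but at the limit of > 20000 nM in this assay, at which 2 of the 3 values shown sit. The step to it from compound 1, an at least 1.1-fold higher number from compound 1 to compound 3 (0.04 log units; that floor lies within the scatter), has a floor that lies within the scatter, and the step from compound 2, a step that the two limits leave unreadable from compound 2 to compound 3, cannot be read from two limits.

Compound 4 `Cc1ccc(-c2nn(-c3ccc(F)cc3F)cc2CNCCN2CCN(C)CC2)cc1` differs from compound 3 by one change: methyl in place of dimethylsulfamoyl on an aromatic carbon. Within the data shown here, no measured step covers this exact change; the nearest, the one from compound 1 to compound 3, gave no readable movement, and neither compound 2 nor compound 3 left the limit. Compound 4 is therefore expected to show a number no higher from compound 3 to compound 4 (the limit leaves the size open), that is, no step beyond the scatter. The estimate for compound 4 is 20000 nM, with a range from 10000 nM to 40000 nM, and it is expected most likely to be reported again only as a limit.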

Compound 4, half-maximal cytotoxic concentration: > 20000 nM
Compound 4 ended at the assay's limit; the forecaster's own chance of this, stated with the estimate: 65%; the middle value sits exactly at the limit.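

In this assay, a small methyl now joins hydrogen and the much larger dimethylsulfamoyl at the aromatic carbon para to a large group, and all three give the same reading, which is a limit and not a number: the limit of > 20000 nM in this assay, at which 3 of the 4 values shown sit.

Going from 4-(dimethylsulfamoyl)phenyl to 4-methylphenyl replaces a group of 6 heavy atoms with a single carbon, yet the steps from compound 2 and compound 3 to compound 4 cannot be read, as both ends of each are limits. Among these compounds, the one step that can be read is an at least 1.1-fold higher number from compound 1 to compound 4 (0.04 log units; that floor lies within the scatter), so it shows no difference beyond the scatter.

The compounds shown leave open where these three compounds truly lie beyond the limit. They also leave open whether an amine or a carboxylic acid at this position would give a reading below it.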